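A few compounds are considered here, and "the series" means these few. Any claim that something is new, unique, unknown or untested is made for them only; others in the source may bear on it.

In a functional assay on HeLa cells (Homo sapiens) for antiproliferative activity, read by CCK-8 assay, with a stated time of 72 h, tested at 2 uM (on this read-out higher numbers stand for a stronger effect at the one concentration tested and lower numbers for a weaker effect), the three measured compounds give:
compound 1 `Nc1ccccc1NC(=O)c1ccc(CSC(=S)N2CCN(Cc3ccccn3)CC2)cc1`: 14.2%
compound 2 `Nc1ccccc1NC(=O)c1ccc(CSC(=S)N2CCN(c3cccnc3)CC2)cc1`: 66.2%
compound 3 `CN1CCN(C(=S)SCc2ccc(C(=O)Nc3ccccc3N)cc2)CC1`: 52.6%

Among these numbers compound 3 stands second highest: its nearest neighbour is compound 2, whose number lies higher by a step beyond the scatter, and its furthest is compound 1, which lies well below it. Compound 4 `Nc1ccccc1NC(=O)c1ccc(CSC(=S)N2CCN(c3ncccn3)CC2)cc1` is not yet measured and differs from compound 3 in one place: pyrimidin-2-yl in place of methyl on an amine nitrogen in a ring. Going by the values given here, two measured steps bear on this change. The step of a number 13.6 percentage points lower from compound 2 to compound 3 (beyond the scatter) is the closest comparison, as it also exchanges a six-membered aromatic ring on the amine nitrogen in the ring for a methyl, only in the opposite direction. The step of a number 52 percentage points higher from compound 1 to compound 2 (beyond the scatter) shows that a pyridin-3-yl on that nitrogen gives a far higher number than a (pyridin-2-yl)methyl, and a number 38.4 percentage points higher from compound 1 to compound 3 (beyond the scatter) shows that even the methyl stands well above the (pyridin-2-yl)methyl. On this basis a modest rise beyond the scatter in this assay is expected for compound 4, bringing it roughly back to the level of compound 2, an expected step of a number 9.4 percentage points higher from compound 3 to compound 4 (within the scatter). Compound 4 is thus estimated at 62%, with a range from 45% to 78%.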

Compound 4, a percentage reported as inhibition, at one concentration (the size of the read-out at that concentration, not a potency): 52.2%
The estimate for compound 4 lay 9.8 percentage points above the measured number; the measured number falls inside the stated range.
By their numbers in this assay, from the lowest: compound 1; then compounds 4 and 3 (each within the scatter of the next); then compound 2.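

In this assay, going by these compounds alone, pyrimidin-2-yl on the amine nitrogen in the ring reads level with methyl (a number 0.4 percentage points lower from compound 3 to compound 4 (within the scatter)), so this place takes a six-membered aromatic ring with 2 hetero atoms and the number stays with that of the single carbon group. Until now pyridin-3-yl was the only aromatic ring set directly on this nitrogen, and the new comparison shows that such a ring does not by itself reach the number of compound 2 (a number 14 percentage points lower from compound 2 to compound 4 (beyond the scatter)), a modest step that comes with the exchange of pyridin-3-yl for pyrimidin-2-yl alone. All three groups set directly on this nitrogen stand well above the (pyridin-2-yl)methyl, the new one included (a number 38 percentage points higher from compound 1 to compound 4 (beyond the scatter)), which leaves compound 1 as the single low point among the four compounds.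

The compounds shown leave open whether a phenyl or a pyridin-4-yl on this nitrogen would stand with compound 2 or with compound 4, and whether a pyridin-3-ylmethyl would fall as low as compound 1. Nothing among the data offers an explanation for any of these differences.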